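Shrinking a Ring on the Amide Nitrogen

The source may hold more compounds than are shown below. What is called first, only, known or untested is meant among the compounds shown, and "the series" means these compounds.

Of the compounds shown here, three built on one shared core have been tested in a functional assay on HBL-100 cells (Homo sapiens) for cytotoxicity, read by MTT assay, with a stated time of 72 h; a lower number here means a stronger inhibitor, a higher number a weaker inhibitor. Compound 1, `C#CCn1cc(C(=O)NC(CC(=O)Nc2ccccn2)c2ccccc2)c(=O)c2ccc(Cl)nc21`, gives only a limit of the assay there, > 10000 nM. Compound 2, `C#CCn1cc(C(=O)NC(CC(=O)NC2CCCCC2)c2ccccc2)c(=O)c2cc(F)c(Cl)nc21`, likewise gives only a limit in this assay, > 10000 nM. Compound 3, `C#CCn1cc(C(=O)NC(CC(=O)Nc2ccccc2)c2ccccc2)c(=O)c2ccc(Cl)nc21`, gives a number in this assay, 4000 nM. Going by the values given here, the one step that can be read between measured compounds is an at least 2.5-fold lower number from compound 1 to compound 3 (0.39 log units; beyond the scatter). Compound 2 therefore stands at the edge of what this assay reports, as described by the limit of > 10000 nM in this assay, at which 2 of the 3 values shown sit, and has no number of its own.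

Compound 4, `C#CCn1cc(C(=O)NC(CC(=O)NC2CCCC2)c2ccccc2)c(=O)c2cc(F)c(Cl)nc21`, differs from compound 2 in one place: cyclopentyl in place of cyclohexyl on an amide-type nitrogen. Among the compounds with values here, no measured step swaps one saturated ring for another. The step from compound 1 to compound 3 also alters the group on an amide-type nitrogen, yet there one aromatic ring replaces another, which makes it only a loose guide for the present change. Compound 2 begins at a limit, and the change is a small one. Compound 4 is expected to stay near that limit, with the step that the limit leaves unreadable from compound 2 to compound 4 estimated to lie within the scatter. The estimate for compound 4 in this assay is 15000 nM, between 4000 nM and 50000 nM.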

Compound 4, half-maximal inhibitory concentration: 2000 nM
Estimate against measurement, compound 4: 7.5-fold (0.88 log units) above, and the stated range ends above it.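

In this assay, the group on this amide-type nitrogen matters even when one saturated carbon ring replaces another, a kind of change that the earlier step between two aromatic rings could not address. Going from six carbons to five, with no hydrogen-bond donor or acceptor on either ring, gives an at least 5.0-fold lower number from compound 2 to compound 4 (0.69 log units; beyond the scatter), so the ring's size alone is enough to separate these two compounds. That step has only a lower bound, and its true size remains unknown because compound 2 has a limit of the assay and not a number of its own: the limit of > 10000 nM in this assay, at which 2 of the 4 values shown sit.

From the compounds shown here alone, two saturated rings cannot establish a trend with ring size, so it remains open whether cyclobutyl, cycloheptyl or an open chain such as isopropyl would fit the same picture. Going by these compounds, it is also open whether a ring carrying an amine or a carboxylic acid would keep the value seen for compound 4, and whether swapping cyclohexyl for cyclopentyl would give a similar step on the core of compound 1.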